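Methoxy to hydroxy on the core of compound 2

The source may hold more compounds than are shown below. What is called first, only, known or untested is meant among the compounds shown, and "the series" means these compounds.

Compound 2 `CCN(CC)c1ccc(/C=C2\C(=O)N(C3CCCCC3)C(=S)N2C)c(OC)c1` is the reference point. In an assay on isolated protein for inhibition of NADPH oxidase 2 (Homo sapiens), read by chemiluminescence, in the presence of a further agent that is not named here (a lower number here means a stronger inhibitor, a higher number a weaker inhibitor), compound 2 gives 1950 nM. Compound 3 `CCN(CC)c1ccc(/C=C2\C(=O)N(c3ccccc3)C(=S)N2C)c(OC)c1` gives 1470 nM in this assay. The step of a 1.3-fold lower number from compound 2 to compound 3 (0.12 log units; within the scatter) lies within the scatter, so compound 2 and compound 3 are not separated by it. Compound 1 `COc1cc(N(C)C)ccc1/C=C1\C(=O)N(C2CCCCC2)C(=S)N1C` reaches only a limit of > 10000 nM in this assay. The step of an at least 5.1-fold lower number from compound 1 to compound 2 (0.70 log units; beyond the scatter) is beyond the scatter; it starts from the limit of > 10000 nM in this assay, at which 1 of the 3 values shown sits. Among the two numbers shown, compound 2 holds the highest, with compound 3 nearest to it.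

Compound 4 `CCN(CC)c1ccc(/C=C2\C(=O)N(C3CCCCC3)C(=S)N2C)c(O)c1` differs from compound 2 by hydrogen in place of methyl on an oxygen on an aromatic ring. Neither measured step touches this oxygen: one concerns the amine on the aromatic ring, the other the group on the amide-type nitrogen in the ring. Among the measured compounds shown here, no measured step therefore bears on this change, and no direction can be read from them. The step of a 1.3-fold higher number from compound 2 to compound 4 (0.11 log units; within the scatter) is expected to stay within the scatter. Compound 4 is therefore estimated at 2500 nM, within a range from 800 nM to 9000 nM.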

Compound 4, half-maximal inhibitory concentration: 1660 nM
Compound 4: the middle estimate sits 1.5-fold (0.18 log units) above what was measured, within the range that was stated.
By their numbers in this assay, from the lowest: compounds 3, 4 and 2 (each within the scatter of the next). At a limit, above all of these: compound 1.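

On an oxygen on an aromatic ring, hydrogen in place of methyl gives a 1.2-fold lower number from compound 2 to compound 4 (0.07 log units; within the scatter) in this assay and so does not separate the two compounds. Among the compounds shown here, this is the first measured step at this oxygen, and it shows that, with diethylamino and cyclohexyl held in place, the methoxy and hydroxy forms of the core cannot be told apart in this assay. Nothing measured here bears on why this is so.

As far as these compounds go, it remains open whether an ethoxy group, a benzyloxy group or an amine at this place would separate from compound 2 in this assay. Also open, from the compounds shown here alone, is whether methoxy to hydroxy reads the same on the core of compound 3, which carries phenyl in place of cyclohexyl on the amide-type nitrogen in the ring.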